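Selenocyanate to thiocyanate swap on the amide side chain

A few compounds are considered here, and "the series" means these few. Any claim that something is new, unique, unknown or untested is made for them only; others in the source may bear on it.

Compound 1 `CC(=O)Oc1ccccc1C(=O)NCC[Se]C#N`: 2600 nM
Compound 2 `CC(=O)Oc1ccccc1C(=O)OCC[Se]C#N`: 15100 nM

Going by the values given here, in a functional assay on PANC-1 cells (Homo sapiens) for antiproliferative activity, read by MTT assay, with a stated time of 72 h (on this read-out lower numbers stand for stronger inhibition and higher numbers for weaker inhibition), compound 1 gives 2600 nM and compound 2 gives 15100 nM; compound 1 stands at the lower of the two numbers, with a 5.8-fold higher number from compound 1 to compound 2 (0.76 log units; beyond the scatter) the only measured step. Compound 3 `CC(=O)Oc1ccccc1C(=O)NCCSC#N` differs from compound 1 by a group of 3 heavy atoms (1 carbon, 1 nitrogen, 1 sulfur; no ring) in place of a group of 3 heavy atoms (1 carbon, 1 nitrogen, 1 selenium; no ring), on a saturated chain carbon, two bonds along the chain from an amide-type nitrogen. Among the compounds with values here, no measured step touches this place: the one known step concerns the carbonyl carbon and does not bear on the swap, leaving its direction open. For compound 3 a modestly higher number than for compound 1 is expected, a 2.3-fold higher number from compound 1 to compound 3 (0.36 log units; beyond the scatter). The estimate for compound 3 is 6000 nM, within 2000 nM to 20000 nM.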

Compound 3, half-maximal inhibitory concentration: 8700 nM
Estimate against measurement, compound 3: 1.5-fold (0.16 log units) below, within the range that was stated.
By their numbers in this assay, from the lowest: compound 1; then compounds 3 and 2 (each within the scatter of the next).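

At the saturated chain carbon, two bonds along the chain from an amide-type nitrogen, the selenium-to-sulfur swap registers on its own: cyanosulfanyl in place of the selenium group gives a 3.3-fold higher number from compound 1 to compound 3 (0.52 log units; beyond the scatter) in this assay. The step on the carbonyl carbon reads a 1.7-fold lower number from compound 2 to compound 3 (0.24 log units; within the scatter), so the sulfur amide and the selenium ester are not told apart on this read-out. No measurement at hand gives a cause for either step.

Still open, on these data alone, is how an amine in place of the cyanosulfanyl group would read. As far as these compounds go, a longer chain between the amide nitrogen and that group also remains open.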